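A Methyl on the Ring Amine of Compound 3

The compounds below may be only part of what the source reports. "The series", "measured", "known", "first", "only" and "open" are said of these compounds alone.

Four compounds share one core and differ in two places. Compound 1 `CCn1cc(-c2nc3ccc([N+](=O)[O-])cc3[nH]2)c(=O)c2cc(F)c(N3CCNCC3)cc21` carries a nitro group and an unsubstituted ring amine; in a functional assay on KB cells (Homo sapiens) for cytotoxicity, read by MTT assay, with a stated time of 48 h (on this read-out lower numbers stand for stronger inhibition and higher numbers for weaker inhibition), compound 1 gives 1100 nM. Compound 2 `CCn1cc(-c2nc3ccc([N+](=O)[O-])cc3[nH]2)c(=O)c2cc(F)c(N3CCN(C)CC3)cc21` differs from compound 1 only by methyl in place of hydrogen on an amine nitrogen in a ring, and in this assay compound 2 gives 2500 nM; the step is a 2.3-fold higher number from compound 1 to compound 2 (0.36 log units; beyond the scatter). Compound 3 `CCn1cc(-c2nc3ccc(N)cc3[nH]2)c(=O)c2cc(F)c(N3CCNCC3)cc21` keeps the unsubstituted ring amine of compound 1 but changes the group on the aromatic ring; in this assay compound 3 gives 35400 nM, the highest number of the three, and the step is a 32-fold higher number from compound 1 to compound 3 (1.51 log units; beyond the scatter).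

Compound 4 `CCn1cc(-c2nc3ccc(N)cc3[nH]2)c(=O)c2cc(F)c(N3CCN(C)CC3)cc21` has not yet been measured. It stands to compound 3 as compound 2 stands to compound 1: the difference is methyl in place of hydrogen on an amine nitrogen in a ring, and the two place descriptions read word for word alike, so this is the same kind of change. The two cores differ by amino in place of nitro on an aromatic carbon.

The expectation for compound 4 rests on the earlier pair, where the methyl-for-hydrogen step gave a 2.3-fold higher number from compound 1 to compound 2 (0.36 log units; beyond the scatter). Applied to compound 3, the same kind of step is estimated at a 2.3-fold higher number from compound 3 to compound 4 (0.35 log units; beyond the scatter), because compound 3 gives 35400 nM, which already lies far up the scale, and a step of the same kind is expected to move it further in the same direction. In this assay compound 4 is therefore expected to give about 80000 nM, with a likely range from 30000 nM to 200000 nM, and there is some chance that only a limit is reported.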

Compound 4, half-maximal inhibitory concentration: > 50000 nM
Compound 4: a limit, no number; the forecaster's own chance of this, stated with the estimate: 25%; the middle value does not contradict the limit.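

In this assay compound 4 gives > 50000 nM, which is a limit of the assay and not a number. Read against the amino core, methyl in place of hydrogen on the ring amine gives an at least 1.4-fold higher number from compound 3 to compound 4 (0.14 log units; that floor lies within the scatter), so the data do not establish a rise on this core on their own, and they cannot say whether the step has the same size as on the nitro core: the same change on two cores in this assay, a 2.3-fold higher number (0.36 log units; beyond the scatter) from compound 1 to compound 2 and an at least 1.4-fold higher number (0.14 log units; that floor lies within the scatter) from compound 3 to compound 4; the limit leaves it open whether they differ The change of nitro to amino carries across more clearly, since an at least 20-fold higher number from compound 2 to compound 4 (1.30 log units; beyond the scatter) is a large step beyond the scatter and runs in the same direction as on the core with the unsubstituted ring amine, although only its floor is known and not its size: the same change on two cores in this assay, a 32-fold higher number (1.51 log units; beyond the scatter) from compound 1 to compound 3 and an at least 20-fold higher number (1.30 log units; beyond the scatter) from compound 2 to compound 4; the limit leaves it open whether they differ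

The compounds shown leave open how a longer chain such as ethyl or propyl on the same ring nitrogen would read in this assay, on either the nitro or the amino core. They also leave open whether a different group on that aromatic carbon, such as an acetamide or a nitrile, would give a number closer to that of the nitro compounds or to that of the amino compounds.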